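Trimethoxyphenyl pyrazole chalcones: a methoxy removed

The source may report more compounds than this note shows. Statements on the series, on what has been measured and on what is new or still open speak of the compounds shown alone.

Measured compounds:
compound 1, `COc1cc(-c2cc(/C=C/C(=O)c3ccc(N)cc3)[nH]n2)cc(OC)c1OC`, 105%
compound 2, `COc1cc(-c2cc(/C=C/C(=O)c3ccc(Cl)c(Cl)c3)[nH]n2)cc(OC)c1OC`, 106%
compound 3, `COc1ccc(C(=O)/C=C/c2cc(-c3cc(OC)c(OC)c(OC)c3)n[nH]2)cc1OC`, 96%

In a functional assay on OVCAR-4 cells (Homo sapiens) for cytotoxicity, read by sulforhodamine B assay, with a stated time of 48 h, tested at 0.1 uM (on this read-out lower numbers stand for a stronger effect and higher numbers for a weaker effect at the one concentration tested), the three measured compounds all lie close together. Compound 3 gives 96%, the lowest of the three numbers, but both steps that lead to it stay within the scatter: a number 9 percentage points lower from compound 1 to compound 3 (within the scatter) and a number 10 percentage points lower from compound 2 to compound 3 (within the scatter), so no order among them can be claimed. Going by the values given here, the only change across the measured set was the aryl group on the carbonyl carbon: a number 1 percentage points higher from compound 1 to compound 2 (within the scatter), also within the scatter.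

Compound 4, `COc1ccc(C(=O)/C=C/c2cc(-c3cc(OC)c(OC)c(OC)c3)n[nH]2)cc1`, differs from compound 3 in one place: hydrogen in place of methoxy on an aromatic carbon. Among the compounds with values here, no measured step touches this position; the changes that were measured, all at the same aryl group, left the read-out unmoved. On that basis compound 4 is expected to stay where compound 3 stands, with a number 2 percentage points higher from compound 3 to compound 4 (within the scatter) expected to lie within the scatter. Compound 4 is therefore estimated at 98%, between 85% and 110%.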

Compound 4, a percentage reported as activity, at one concentration (the size of the read-out at that concentration, not a potency): 94%
Compound 4: middle estimate off by 4 percentage points, on the high side, and the stated range covers the measured number.
By their numbers in this assay, from the lowest: compounds 4, 3, 1 and 2 (each within the scatter of the next, the first and the last beyond it).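

In this assay, going by these compounds alone, the first change at this aromatic carbon, hydrogen in place of methoxy, gives a number 2 percentage points lower from compound 3 to compound 4 (within the scatter) and so leaves the 3,4-dimethoxyphenyl and 4-methoxyphenyl compounds indistinguishable on this read-out. Within the data shown here, compound 4 also brings the first steps in the set that pass beyond the scatter: there is a number 12 percentage points lower from compound 2 to compound 4 (beyond the scatter) and there is a number 11 percentage points lower from compound 1 to compound 4 (beyond the scatter) in the same direction, both of them modest. No measurement shown here gives a reason for these steps.

From the compounds shown here alone, whether the methoxy remaining on the ring of compound 4 matters stays open, as does the read-out with a hydroxy group or a fluorine atom on this aromatic carbon. Going by these compounds, all the numbers stand at one low concentration, so how these compounds would separate at higher concentrations also remains unknown.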